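Diphosphate and monophosphate uracil nucleotides as P2Y4 agonists

This account rests on a few compounds, and the source may have more. Where it says the series, first, only, none or still open, it means among the compounds named here.

For the measured compounds named here, compound 2 `O=c1ccn([C@@H]2O[C@H](COP(=O)(O)OP(=O)(O)O)[C@@H](O)[C@H]2O)c(SCc2ccccc2)n1` is the only member of the set with a number in an in vitro functional assay on 1321-N1 cells for agonist activity at P2Y purinoceptor 4 (Homo sapiens), read by scintillation proximity assay and inositol phosphate accumulation; on this read-out higher numbers stand for an effect only at larger amounts of compound and lower numbers for an effect already at smaller amounts: compound 2 gives 5980 nM. Compound 3 `O=c1ccn([C@@H]2O[C@H](COP(=O)(O)O)[C@@H](O)[C@H]2O)c(SCc2ccccc2)n1` reaches only a limit of the assay, and in this assay compound 3 gives > 100000 nM. Compound 1 `CNc1nc(=O)ccn1[C@@H]1O[C@H](COP(=O)(O)O)[C@@H](O)[C@H]1O` likewise sits at a limit; in this assay compound 1 gives > 100000 nM. Two of the three values thus rest on (the limit of > 100000 nM in this assay, at which 2 of the 3 values shown sit).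

Compound 3 and compound 2 differ in a group of 4 heavy atoms (3 oxygen, 1 phosphorus; no ring) in place of a hydrogen atom, on an oxygen. This change produces an at least 16-fold higher number from compound 2 to compound 3 (1.22 log units; beyond the scatter). Compound 3 and compound 1 differ in methylamino in place of benzylsulfanyl on an aromatic carbon, but with both values at a limit the result is a step that the two limits leave unreadable from compound 3 to compound 1, so no size can be read for it.

Compound 4 `CNc1nc(=O)ccn1[C@@H]1O[C@H](COP(=O)(O)OP(=O)(O)O)[C@@H](O)[C@H]1O` is not yet measured. It differs from compound 2 in methylamino in place of benzylsulfanyl on an aromatic carbon, the same change as from compound 3 to compound 1, at the same place. Since that earlier step gives no readable size, the expectation for compound 4 rests on compound 2 alone, whose 5980 nM is the only anchor. Both monophosphate compounds sit at a limit of the assay. A step of a 2.5-fold higher number from compound 2 to compound 4 (0.40 log units; beyond the scatter) is expected, held loosely. Compound 4 is accordingly estimated at 15000 nM, between 2000 nM and 100000 nM, with a real chance that only a limit is returned.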

Compound 4, half-maximal effective concentration: >= 100000 nM
Compound 4 gave a limit, no number; the forecaster's own chance of this, stated with the estimate: 30%; middle value at least 6.6-fold (0.82 log units) from the limit.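

In this assay compound 4 gives >= 100000 nM, which is a limit of the assay and not a number. On the diphosphate core of compound 2, methylamino in place of benzylsulfanyl on an aromatic carbon therefore gives an at least 16-fold higher number from compound 2 to compound 4 (1.22 log units; beyond the scatter), and the true size of this step may be larger still, so the series holds no number for a methylamino compound. This does not show how the change carries from one core to another: the same change on the monophosphate core, from compound 3 to compound 1, cannot be read, nor can the addition of the terminal phosphate from compound 1 to compound 4, and with both ends of each pair at a limit, the two cores cannot be compared: the limit of > 100000 nM in this assay, at which 2 of the 4 values shown sit.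

Still open, from the compounds shown here alone, is whether the number for compound 2 depends on the benzyl group, on the sulfur or on both, and benzylamino or methylsulfanyl on the same aromatic carbon of the diphosphate core would separate these two parts. Also open, going by these compounds, is how a triphosphate chain in place of the diphosphate would read with either benzylsulfanyl or methylamino on that carbon.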